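Swapping a furan for an ethoxyphenyl on a shared core

This account rests on a few compounds, and the source may have more. Where it says the series, first, only, none or still open, it means among the compounds named here.

Measured compounds:
- compound 1, `Cc1ccccc1-n1nc(C)c2c1NC(=O)[C@H](C)S[C@@H]2c1ccc(-c2ccoc2)cc1`: 3500 nM
- compound 2, `COc1ccccc1-n1nc(C)c2c1NC(=O)[C@H](C)S[C@@H]2c1ccc(Oc2ccccc2)cc1`: 3300 nM
- compound 3, `Cc1nn(-c2ccccc2C(F)(F)F)c2c1C(c1ccc(Oc3ccccc3)cc1)SC(C)C(=O)N2`: 2000 nM

All three were tested in an assay on isolated protein for agonist activity at Bile acid receptor (Homo sapiens), read by AlphaScreen, with a stated time of 30 min; a higher number here means that more compound is needed for the effect, a lower number that less compound is needed. In this assay compound 1 gives 3500 nM, compound 2 gives 3300 nM and compound 3 gives 2000 nM. Compound 1 sits alongside the other two: its gaps to compound 2 and to compound 3 are both within the usual scatter, so none of the three can be said to need more or less compound than another.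

The unmeasured compound 4, `CCOc1cccc(-c2ccc([C@H]3S[C@@H](C)C(=O)Nc4c3c(C)nn4-c3ccccc3C)cc2)c1`, is built from compound 1 by one change: 3-ethoxyphenyl in place of furan-3-yl on an aromatic carbon. For the measured compounds named here, no pair of measured compounds differs in just this one place, so there is no directly comparable step. What the data do show is that compound 2 and compound 3, which carry a six-membered aromatic ring with an oxygen-linked group at the same end of the molecule, give values close to that of compound 1.

On that basis compound 4 is expected to land near compound 1, perhaps slightly lower, with a step of a 1.6-fold lower number from compound 1 to compound 4 (0.20 log units; within the scatter) that stays within the usual scatter. The estimate for compound 4 in this assay is 2200 nM, with a range from 700 nM to 7000 nM.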

Compound 4, half-maximal effective concentration: 3500 nM
Compound 4: the middle estimate sits 1.6-fold (0.20 log units) below what was measured; measured number inside the range.
By their numbers in this assay, from the lowest: compounds 3, 2, 1 and 4 (each within the scatter of the next).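

In this assay, for the compounds shown here, replacing furan-3-yl with 3-ethoxyphenyl gives no change at the digits printed from compound 1 to compound 4 (within the scatter), and this is the first direct one-place comparison at this position on an aromatic carbon, para to a large group. The change is not small on paper: a five-membered aromatic ring with one hetero atom gives way to a six-membered aromatic ring of carbon only, and the group grows from 5 heavy atoms to 9, yet the number does not move, so on the shared core of these two compounds this position accepts both groups alike in this test. Nothing measured here explains why the value holds steady.

From the compounds shown here alone, both groups carry one hydrogen-bond acceptor and no donor and neither has a net charge, so it remains open whether an amine or a carboxylic acid on this ring would shift the number. It is also unknown whether a longer chain in place of the ethoxy group would keep it level, or whether the same swap would behave alike on a core carrying different groups elsewhere.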